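Nitro for Chloro: Expected Cytotoxicity of Compound 4

This account rests on a few compounds, and the source may have more. Where it says the series, first, only, none or still open, it means among the compounds named here.

Measured in an ADME assay on MRC5 cells (Homo sapiens) for cytotoxicity, read by fluorescence, with a stated time of 24 h; on this read-out higher numbers stand for weaker inhibition and lower numbers for stronger inhibition:
compound 1, `O=C1CS/C(=N/N=C/c2c(-c3ccc(Cl)cc3)[nH]c3ccccc23)N1Cc1ccco1`, gives 10800 nM.
compound 2, `CCOC(=O)c1sc(N/N=C/c2c(-c3ccc(Cl)cc3)[nH]c3ccccc23)nc1C`, gives 25200 nM.
compound 3, `O=C(CC1S/C(=N\N=C\c2c(-c3ccccc3)[nH]c3ccccc23)NC1=O)c1ccccc1`, reaches only the assay limit > 50000 nM.

Compound 2 holds the highest of the two numbers recorded in this assay; the nearest is compound 1, whose number is lower by a gap beyond the scatter. Compound 3 stands at a limit only, as stated in the limit of > 50000 nM in this assay, at which 1 of the 3 values shown sits. Compound 4, `CCOC(=O)c1sc(N/N=C/c2c(-c3ccc([N+](=O)[O-])cc3)[nH]c3ccccc23)nc1C`, differs from compound 2 by nitro in place of chloro on an aromatic carbon. Going by the values given here, no measured pair shows this change, so a step of about the size of the scatter, in either direction, is expected in this assay. Compound 4 is estimated at 30000 nM, between 10000 nM and 80000 nM. The expected step is a 1.2-fold higher number from compound 2 to compound 4 (0.08 log units; within the scatter).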

Compound 4, half-maximal inhibitory concentration: 23500 nM
Estimate against measurement, compound 4: 1.3-fold (0.11 log units) above; measured number inside the range.
By their numbers in this assay, from the lowest: compound 1; then compounds 4 and 2 (each within the scatter of the next). At a limit, above all of these: compound 3.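

In this assay, 4-nitrophenyl in place of 4-chlorophenyl gives a 1.1-fold lower number from compound 2 to compound 4 (0.03 log units; within the scatter) on the shared core. This is the only pair shown that differs in one place, and it shows that this position, para to a large group, accepts nitro for chloro with no change beyond the scatter. Nothing shown explains why the two compounds read alike.

From the compounds shown here alone, whether an amine or a carboxylic acid at this position would also stay within the scatter remains open. So does whether the same change would read alike on the core of compound 1.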